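Swapping Methoxy for Methyl on a Tolerated Side Group

The compounds below may be only part of what the source reports. "The series", "measured", "known", "first", "only" and "open" are said of these compounds alone.

In an ADME assay on Vero cells (Chlorocebus sabaeus) for cytotoxicity (a higher number here means that more compound is tolerated, a lower number that less compound is tolerated), compound 2 `CCN(CC)CN1C(=O)/C(=N/NC(=S)Nc2ccc(OC)cc2)c2cc(Cl)ccc21` gives 4000 nM, the only plain number shown. Compound 1 `CCN(CC)CN1C(=O)/C(=N/NC(N)=S)c2cc(Cl)ccc21` gives > 100000 nM, which is the limit of > 100000 nM in this assay, at which 1 of the 2 values shown sits, rather than a measured number. Among the measured compounds shown here, the one measured step, an at least 25-fold lower number from compound 1 to compound 2 (1.39 log units; beyond the scatter), came from attaching a whole 4-methoxyphenyl group, a far larger change than the one ahead. Compound 3 `CCN(CC)CN1C(=O)/C(=N/NC(=S)Nc2ccc(C)cc2)c2cc(Cl)ccc21` differs from compound 2 by methyl in place of methoxy on an aromatic carbon. For the measured compounds named here, no measured step touches this small change, so nothing beyond the usual scatter is expected: compound 3 is estimated at 4000 nM, between 2000 nM and 8000 nM, meaning no change at the digits printed from compound 2 to compound 3 (within the scatter).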

Compound 3, minimum cytotoxic concentration: >= 4000 nM
Compound 3 was reported as a limit; the forecaster's own chance of this, stated with the estimate: 5%; the middle value sits exactly at the limit.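

In this assay methyl in place of methoxy, on an aromatic carbon para to a large group, gives a number no lower from compound 2 to compound 3 (the limit leaves the size open) and so the swap brings no lower number at this position. What compound 3 shows is a limit and not a number: the limit of >= 4000 nM in this assay, at which 1 of the 3 values shown sits. The step from compound 1 to compound 3 cannot be read. Going by these compounds, whether methyl raises the number at all stays open, and so does what an amine or a carboxylic acid at this position would do.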